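Adding a Second Chloro to a Cytotoxicity-Silent Triazole

The source may hold more compounds than are shown below. What is called first, only, known or untested is meant among the compounds shown, and "the series" means these compounds.

Compound 1 `O=[N+]([O-])c1cc(CSc2nnc(-c3ccccc3)n2Cc2ccccc2)cc([N+](=O)[O-])c1` and compound 2 `O=[N+]([O-])c1cc(CSc2nnc(-c3ccc(Cl)cc3)n2Cc2ccccc2)cc([N+](=O)[O-])c1` share one core, while compound 3 `O=[N+]([O-])c1cc(-c2nnc(SCc3ccc(Cl)cc3)n2Cc2ccccc2)cc(C(F)(F)F)c1` is built on another; the difference between the two cores is not broken down here. In an ADME assay on HepG2 cells (Homo sapiens) for cytotoxicity, with a stated time of 48 h (on this read-out higher numbers stand for weaker inhibition and lower numbers for stronger inhibition), compound 1 reaches only a limit of the assay, > 30000 nM. Compound 2 likewise reaches only a limit, > 30000 nM. Compound 3 also gives only a limit, > 30000 nM. The change from compound 1 to compound 2 is chloro in place of hydrogen on an aromatic carbon, and the step it made, a step that the two limits leave unreadable from compound 1 to compound 2, cannot be read because of the limit of > 30000 nM in this assay, at which 3 of the 3 values shown sit. Compound 4 `O=[N+]([O-])c1cc(-c2nnc(SCc3ccc(Cl)c(Cl)c3)n2Cc2ccccc2)cc(C(F)(F)F)c1` is not yet measured and arises from compound 3 by chloro in place of hydrogen on an aromatic carbon. This is the same kind of change, though the surroundings differ: in compound 4 the entering chloro sits ortho to a chloro group and meta to a large group, whereas in compound 2 it sits para to a large group. Since every measured value here sits at the limit, no readable step guides the expectation, and the step from compound 3 to compound 4 is expected to be a number no higher from compound 3 to compound 4 (the limit leaves the size open). Compound 4 is therefore expected to give 30000 nM, most probably again only a limit, within an expected range from 15000 nM to 60000 nM.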

Compound 4, half-maximal inhibitory concentration: > 30000 nM
Compound 4 ended at the assay's limit; the forecaster's own chance of this, stated with the estimate: 85%; the middle value lies on the limit itself.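

No step can be read from compound 3 to compound 4, nor from compound 1 to compound 2, because each of these compounds gives only a limit in this assay: the limit of > 30000 nM in this assay, at which 4 of the 4 values shown sit. The compounds shown leave open how strongly any of them inhibits these cells, and whether adding a chloro changes that at all.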